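Benzyloxy added to compound 3: what follows in potency

This account rests on a few compounds, and the source may have more. Where it says the series, first, only, none or still open, it means among the compounds named here.

Compound 1 `CCOC(=O)c1cc(-c2cc(OC)c(OC)c(OC)c2)c(-c2ccc3ccccc3c2)s1`: 1150 nM
Compound 2 `CCOC(=O)c1cc(-c2cc(OC)c(OC)c(OC)c2)c(-c2ccc(OC)c(OCc3ccccc3)c2)s1`: > 100000 nM (a limit of the assay, not a number)
Compound 3 `CCOC(=O)c1cc(-c2ccc(OC)cc2)c(-c2cc(OC)c(OC)c(OC)c2)s1`: 7630 nM

In a functional assay on HT-1080 cells (Homo sapiens) for antiproliferative activity, read by MTT assay, with a stated time of 72 h (a higher number here means a weaker inhibitor, a lower number a stronger inhibitor), compound 3 gives 7630 nM, the higher of the two actual numbers, and the gap down to compound 1 at 1150 nM lies beyond the scatter. Compound 4 `CCOC(=O)c1cc(-c2ccc(OC)c(OCc3ccccc3)c2)c(-c2cc(OC)c(OC)c(OC)c2)s1` differs from compound 3 by benzyloxy in place of hydrogen on an aromatic carbon, ortho to a methoxy group. Among the measured compounds shown here, no measured pair isolates this change. Compound 2, which also carries benzyloxy, returns only a limit, > 100000 nM, so a step towards a higher number in this assay, beyond the scatter, is expected. The estimated step runs a 3.9-fold higher number from compound 3 to compound 4 (0.59 log units; beyond the scatter). For compound 4 the estimated value is 30000 nM, with an expected range of 7000 nM to 100000 nM.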

Compound 4, half-maximal inhibitory concentration: > 100000 nM
Compound 4 ended at the assay's limit (the forecaster's own chance of this, stated with the estimate: 40%); at least 3.3-fold (0.52 log units) between middle value and limit.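

In this assay, benzyloxy in place of hydrogen on an aromatic carbon, ortho to a methoxy group, gives an at least 13-fold higher number from compound 3 to compound 4 (1.11 log units; beyond the scatter), the only step shown between compounds that differ in one place, and a large loss of potency. Compound 4 stands at a limit of the assay and not at a number, so the step fixes only a lower bound on the loss: the limit of > 100000 nM in this assay, at which 2 of the 4 values shown sit. The compounds shown leave open whether a hydroxyl, an ethoxy or an amine on this carbon would keep the activity of compound 3.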